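The source may hold more compounds than are shown below. What is called first, only, known or untested is meant among the compounds shown, and "the series" means these compounds.

Of the compounds shown here, two built on a shared core have been tested in an assay on HT-29 cells for inhibition of Methylated-DNA--protein-cysteine methyltransferase (Homo sapiens); a lower number here means a stronger inhibitor, a higher number a weaker inhibitor. Compound 1 `CCOc1nc(N)nc2[nH]cnc12` gives only a limit there, > 1000000 nM, which the limit of > 1000000 nM in this assay, at which 1 of the 2 values shown sits, records. Within the data shown here, compound 2 `C=C(CC)COc1nc(N)nc2[nH]cnc12` gives 16000 nM, the only real number so far. The step of an at least 62-fold lower number from compound 1 to compound 2 (1.79 log units; beyond the scatter) was a large gain. Compound 3 `Nc1nc(OCC2=CCCC2)c2nc[nH]c2n1` carries a group of 5 heavy atoms (5 carbon; one five-membered non-aromatic ring of carbon only) in place of a group of 4 heavy atoms (4 carbon; no ring), on a saturated chain carbon bound to an oxygen on an aromatic ring. Among the measured compounds shown here, the one measured step enlarged the group; this change instead keeps a group of similar size and closes it into a ring, for which no measured step exists. A change of modest size is therefore expected, a 2.0-fold lower number from compound 2 to compound 3 (0.30 log units; within the scatter). Compound 3 is estimated at 8000 nM, within 2000 nM to 40000 nM.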

Compound 3, half-maximal inhibitory concentration: 390 nM
Compound 3: the middle estimate sits 21-fold (1.31 log units) above what was measured; measured number outside the range, below it.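

At this position, the shape of the group counts as well as its size: in this assay, cyclopent-1-en-1-yl gives a 41-fold lower number from compound 2 to compound 3 (1.61 log units; beyond the scatter), with 5 heavy atoms against 4 and one double bond in each group. Replacing methyl with the same ring gives an at least 2500-fold lower number from compound 1 to compound 3 (3.40 log units; beyond the scatter), a step measured from a limit. Compound 1 gives only a limit: the limit of > 1000000 nM in this assay, at which 1 of the 3 values shown sits.

As far as these compounds go, it remains open whether the ring alone or also its double bond carries this gain, and how a saturated cyclopentyl group or a benzyl group would compare at this place.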